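Methoxy in place of methyl on the aromatic ring of compound 3

The source may hold more compounds than are shown below. What is called first, only, known or untested is meant among the compounds shown, and "the series" means these compounds.

Compound 1 `COC(=O)[C@@]1(C)CCC=C2[C@@H]1CC[C@@H](C)[C@]2(C)Cc1c[nH]c2ccc(Cl)cc12` gives 11000 nM in a functional assay on SW1573 cells (Homo sapiens) for inhibition, read by sulforhodamine B assay, with a stated time of 48 h; on this read-out lower numbers stand for stronger inhibition of growth and higher numbers for weaker inhibition of growth. Compound 2 `COC(=O)[C@@]1(C)CCC=C2[C@@H]1CC[C@@H](C)[C@]2(C)Cc1c(C)[nH]c2ccc(Cl)cc12` gives 14000 nM in this assay; the step of a 1.3-fold higher number from compound 1 to compound 2 (0.10 log units; within the scatter) puts methyl in place of hydrogen on an aromatic carbon. Compound 3 `COC(=O)[C@@]1(C)CC[C@@H]2C3=C1CC[C@@H](C)[C@]3(C)C[C@@H]1c3cc(C)ccc3N[C@H]21` gives 23000 nM in this assay, a number beyond the scatter from compound 1 and within the scatter from compound 2. Compound 4 `COC(=O)[C@@]1(C)CC[C@@H]2C3=C1CC[C@@H](C)[C@]3(C)C[C@@H]1c3cc(OC)ccc3N[C@H]21` differs from compound 3 by methoxy in place of methyl on an aromatic carbon. For the measured compounds named here, no measured step exchanges methoxy for methyl; the only step on an aromatic carbon, a 1.3-fold higher number from compound 1 to compound 2 (0.10 log units; within the scatter), stayed within the scatter. A step within the scatter is therefore expected for compound 4, no change at the digits printed from compound 3 to compound 4 (within the scatter). Compound 4 is estimated at 23000 nM in this assay, between 9000 nM and 55000 nM.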

Compound 4, concentration for 50% growth inhibition: 25000 nM
The estimate for compound 4 lay 1.1-fold (0.04 log units) below the measured number; measured number inside the range.
By their numbers in this assay, from the lowest: compounds 1, 2, 3 and 4 (each within the scatter of the next, the first and the last beyond it).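

For the compounds shown here, on this aromatic carbon, para to a fused ring and meta to a fused ring, the series now has a first reading for a group carrying a hydrogen-bond acceptor: this assay shows a 1.1-fold higher number from compound 3 to compound 4 (0.04 log units; within the scatter) for methoxy in place of methyl. The added oxygen thus leaves compound 4 indistinguishable from compound 3 on this read-out. No measurement at hand accounts for this result. Still open, on these data alone, is whether an amine or a carboxylic acid on this carbon would move the number beyond the scatter from compound 3.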